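The compounds below may be only part of what the source reports. "The series", "measured", "known", "first", "only" and "open" are said of these compounds alone.

Measured in a functional assay on HCT-116 cells (Homo sapiens) for inhibition, read by CCK-8 assay, with a stated time of 48 h; on this read-out lower numbers stand for stronger inhibition and higher numbers for weaker inhibition:
- Compound 1 `COc1cc(-c2ccnc3cc(-c4ccc(N(C)C)cc4)nn23)cc(OC)c1OC`: 2050 nM
- Compound 2 `COc1ccc(-c2cc3nccc(-c4cc(OC)c(OC)c(OC)c4)n3n2)cc1F`: 2840 nM

Among the measured compounds shown here, compound 2, at 2840 nM, cannot be told apart from compound 1, the only other measured compound: the step is a 1.4-fold higher number from compound 1 to compound 2 (0.14 log units; within the scatter). Compound 3 `COc1ccc(-c2cc3nccc(-c4cc(OC)c(OC)c(OC)c4)n3n2)cc1N` has not yet been measured. It keeps the frame of compound 2 and places amino in place of fluoro on an aromatic carbon, ortho to a methoxy group: amino in place of fluoro on an aromatic carbon. For the measured compounds named here, only one measured step bears on this, the exchange of 4-(dimethylamino)phenyl for 3-fluoro-4-methoxyphenyl, and it is a 1.4-fold higher number from compound 1 to compound 2 (0.14 log units; within the scatter). Going by the values given here, no measured pair shows the exchange of fluoro for amino, so the expected lean towards stronger inhibition is a judgement and not a measured trend. The estimated step is a 9.5-fold lower number from compound 2 to compound 3 (0.98 log units; beyond the scatter). Compound 3 is expected at 300 nM, with an estimated range of 20 nM to 3000 nM.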

Compound 3, half-maximal inhibitory concentration: 251 nM
For compound 3 the middle estimate is 1.2-fold (0.08 log units) above the measured one, and the stated range covers the measured number.
By their numbers in this assay, from the lowest: compound 3; then compounds 1 and 2 (each within the scatter of the next).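

In this assay, the aromatic carbon ortho to a methoxy group proves sensitive to a single-atom exchange: amino in place of fluoro gives an 11-fold lower number from compound 2 to compound 3 (1.05 log units; beyond the scatter). The earlier step between aryl groups stayed within the scatter, but 3-amino-4-methoxyphenyl in place of 4-(dimethylamino)phenyl gives an 8.2-fold lower number from compound 1 to compound 3 (0.91 log units; beyond the scatter), so this aryl group now separates from the other two at this position on the shared core. No evidence at hand accounts for the size of the amino step.

The compounds shown leave open whether a hydroxyl, a methylamino or an acetamido group on that carbon would read like amino. They also leave open whether amino would hold its effect with an ethoxy group in place of the methoxy group.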